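Amine variation in a phenyl-substituted series: growth inhibition notes

The source may report more compounds than this note shows. Statements on the series, on what has been measured and on what is new or still open speak of the compounds shown alone.

Compounds measured so far:
compound 1 `Cc1nc(NCc2ccco2)c2cnn(-c3ccccc3)c2n1` with > 100000 nM
compound 2 `CCc1nc(NC(C)C)c2cnn(-c3ccccc3)c2n1` with > 100000 nM
compound 3 `CCCCNc1nc(CC)nc2c1cnn2-c1ccccc1` with 32000 nM

In a functional assay on G-361 cells (Homo sapiens) for cytotoxicity, read by sulforhodamine B assay (a lower number here means a stronger inhibitor of growth, a higher number a weaker inhibitor of growth), compound 1 gives > 100000 nM, a limit of the assay rather than a number. Compound 2 likewise gives > 100000 nM, also a limit. For the measured compounds named here, compound 3 gives 32000 nM, the only number in the set (the limit of > 100000 nM in this assay, at which 2 of the 3 values shown sit). Going by the values given here, the one measured step, an at least 3.1-fold lower number from compound 2 to compound 3 (0.49 log units; beyond the scatter), is at least modest. Compound 4 `CCc1nc(NCc2ccco2)c2cnn(-c3ccccc3)c2n1` differs from compound 3 by furan-2-yl in place of propyl on a saturated chain carbon bound to a nitrogen on an aromatic ring. Among the compounds with values here, no measured step covers this change. The comparison rests on compound 1, which carries the same ((furan-2-yl)methyl)amino group and gives > 100000 nM. For compound 4 a weaker inhibitor is therefore expected, 80000 nM within 25000 nM to 300000 nM. This would mean an estimated 2.5-fold higher number from compound 3 to compound 4 (0.40 log units; beyond the scatter), with a limit rather than a number a real possibility.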

Compound 4, concentration for total growth inhibition: 32000 nM
The estimate for compound 4 lay 2.5-fold (0.40 log units) above the measured number, and the stated range covers the measured number.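

In this assay, the amine position accepts an aromatic ring: furan-2-yl in place of propyl gives no change at the digits printed from compound 3 to compound 4 (within the scatter). (Furan-2-yl)methyl in place of isopropyl gives an at least 3.1-fold lower number from compound 2 to compound 4 (0.49 log units; beyond the scatter), and with the amine held constant, methyl in place of hydrogen on the saturated chain carbon bound to an aromatic carbon gives an at least 3.1-fold lower number from compound 1 to compound 4 (0.49 log units; beyond the scatter), so the group outside the amine also counts. Both of these steps start from a limit and are bounds only: the limit of > 100000 nM in this assay, at which 2 of the 4 values shown sit.

Open, going by these compounds, is whether a longer chain such as hexyl on the amine nitrogen, or a carboxylic acid on the butyl chain, would shift the number shared by compound 3 and compound 4.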